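Thiourea sulfonamides: chain extension on the amide-type nitrogen

The compounds below may be only part of what the source reports. "The series", "measured", "known", "first", "only" and "open" are said of these compounds alone.

Three compounds in the series have been run in a functional assay on the whole organism (blood, strain albino) with Mus musculus as the target, with stated times of 6 days and 4 h, at a dose of 0.4 mmol/kg by the oral route; on this read-out lower numbers stand for less inhibition and higher numbers for more inhibition at the one dose given (going by the name of the read-out). Compound 1 `CCNC(=S)NS(=O)(=O)c1ccc(-n2nc(C(=O)O)cc2C)cc1` gives -2% there. Compound 2 `Cc1cc(C)n(-c2ccc(S(=O)(=O)NC(=S)Nc3ccccc3)cc2)n1` gives -3%, and compound 3 `CCNC(=S)NS(=O)(=O)c1ccc(-n2nc(C)cc2C)cc1` gives 0%. Compound 1 thus sits among the three with a gap to compound 2 that is within the scatter and a gap to compound 3 that is likewise within the scatter; none of the three numbers can be separated from the others.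

Compound 4 `CCCCNC(=S)NS(=O)(=O)c1ccc(-n2nc(C(=O)O)cc2C)cc1` differs from compound 1 in one place: ethyl in place of hydrogen on a saturated chain carbon, two bonds along the chain from an amide-type nitrogen. Going by the values given here, no measured pair carries this exact change. The nearest steps are a number 2 percentage points higher from compound 1 to compound 3 (within the scatter) on the core, and a number 3 percentage points higher from compound 2 to compound 3 (within the scatter) on the same amide-type nitrogen whose chain is lengthened here. Both are within the scatter, and no change tried so far has moved this assay beyond it. On that basis no step beyond the scatter is expected in this assay from compound 1 to compound 4, in either direction; the expected step is a number 2 percentage points higher from compound 1 to compound 4 (within the scatter).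

Compound 4 is accordingly estimated at 0%, with an expected range from -10% to 10%.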

Compound 4, a percentage reported as inhibition, in the whole organism at one dose (the size of the read-out at that dose, not a potency): < 1%
Compound 4 ended at the assay's limit; the forecaster's own chance of this, stated with the estimate: 0%; the middle value does not contradict the limit.
By their numbers in this assay, from the lowest: compounds 2, 1 and 3 (each within the scatter of the next).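

In this assay compound 4 gives < 1%, which is a limit of the assay and not a number. No new step can be read from compound 1 to compound 4, because this value is a limit: the limit of < 1% in this assay, at which 1 of the 4 values shown sits.

The compounds shown leave open whether going from ethylamino to butylamino moves this read-out at all.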